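Phenoxy to 2,2,2-trifluoroethoxy: expected clearance step

The source may report more compounds than this note shows. Statements on the series, on what has been measured and on what is new or still open speak of the compounds shown alone.

Measured in an ADME assay (liver) for pharmacokinetics, with Liver microsome (Rattus norvegicus) as the target, read by LC-MS, using microsomes, tested at 2 uM; on this read-out higher numbers stand for fast clearance and lower numbers for slow clearance:
compound 1 `Cc1c(C(=O)N[C@@H]2CCCC[C@H]2O)cc(-c2cc(C(F)(F)F)ccc2Cl)n1CC1CCCCC1` gives 1.32 mL/min/kg
compound 2 `O=C(N[C@@H]1CCCC[C@H]1O)c1cnc(Oc2ccccc2)c(-c2ccc(Cl)cc2)c1` gives 0.353 mL/min/kg
compound 3 `O=C(N[C@@H]1CCCC[C@H]1O)c1cnc(OC2CCC2)c(-c2ccc(Cl)cc2)c1` gives 0.21 mL/min/kg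
compound 4 `O=C(N[C@@H]1CCCC[C@H]1O)c1cnc(OCC(F)(F)F)c(-c2ccc(Cl)cc2)c1` has no value yet

Compound 2 stands within the scatter of compound 3 and clearly under compound 1 on these numbers. The change leading to compound 4 is 2,2,2-trifluoroethyl in place of phenyl on an oxygen on an aromatic ring and it turns the phenoxy into 2,2,2-trifluoroethoxy. For the measured compounds named here, one measured step bears on it, since cyclobutyl also takes the place of phenyl on an oxygen on an aromatic ring in compound 3. That step is a 1.7-fold lower number from compound 2 to compound 3 (0.23 log units; within the scatter) and it stays within the scatter. Going by the values given here, no measured compound carries the 2,2,2-trifluoroethyl group, so this single step is thin support. No change beyond the scatter is therefore expected in this assay for this replacement. The expected step is a 1.4-fold lower number from compound 2 to compound 4 (0.15 log units; within the scatter) and it stays within the scatter. Compound 4 is estimated at 0.25 mL/min/kg with an expected range of 0.11 mL/min/kg to 0.6 mL/min/kg on present evidence.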

Compound 4, clearance: 0.023 mL/min/kg
Beside the measured number, compound 4's estimate is 11-fold (1.04 log units) above it, outside the stated range (below it).
By their numbers in this assay, from the lowest: compound 4; then compounds 3 and 2 (each within the scatter of the next); then compound 1.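

This position proves far more responsive in this assay than the earlier pair could show: 2,2,2-trifluoroethyl in place of phenyl gives (a 15-fold lower number from compound 2 to compound 4 (1.19 log units; beyond the scatter)) and 2,2,2-trifluoroethyl in place of cyclobutyl gives (a 9.1-fold lower number from compound 3 to compound 4 (0.96 log units; beyond the scatter)). The group on this oxygen can therefore shift clearance beyond the scatter, and among the three groups compared here, phenyl and cyclobutyl stay within the scatter of each other while only the ringless 2,2,2-trifluoroethyl separates. Nothing available on the series accounts for this step.

Going by these compounds, whether the fluorine atoms or the absence of a ring carry the step remains open, and a plain ethyl or a 2,2-difluoroethyl group on the same oxygen would separate the two. On these data alone, whether a longer fluorinated chain, such as 3,3,3-trifluoropropyl, keeps the low clearance also remains open.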